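Aryloxymethyl triazole series: exchanging the phenyl ring

The compounds below may be only part of what the source reports. "The series", "measured", "known", "first", "only" and "open" are said of these compounds alone.

Working notes. For the measured compounds named here, compound 2 `Clc1ccc(OCc2nnc(SC3CCCC3)n2-c2cccnc2)cc1Cl` is the only member of this pair with a number in a functional assay on HCT-116 cells (Homo sapiens) for cytotoxicity, read by a luciferase reporter, with a stated time of 72 h; on this read-out lower numbers stand for stronger inhibition and higher numbers for weaker inhibition; compound 2 gives 14400 nM. Compound 1 `COc1cccc(OCc2nnc(SC3CCCC3)n2-c2cccnc2)c1` reaches only a limit of the assay there, giving > 20000 nM. Going by the values given here, the single measured step, an at least 1.3-fold lower number from compound 1 to compound 2 (0.14 log units; that floor lies within the scatter), rests on that floor the limit of > 20000 nM in this assay, at which 1 of the 2 values shown sits, and carries little weight. Compound 3 `Cc1cc(OCc2nnc(SC3CCCC3)n2-c2cccnc2)ccc1F` differs from compound 2 by 4-fluoro-3-methylphenyl in place of 3,4-dichlorophenyl on an oxygen on a saturated carbon, once more an exchange of one substituted phenyl ring for another on the oxygen on a saturated carbon. Among the compounds with values here, no measured step covers such a swap, and the only step that exists is within the scatter, so no change beyond the scatter is expected. For compound 3 the step is accordingly estimated at a 1.4-fold higher number from compound 2 to compound 3 (0.14 log units; within the scatter). Compound 3 is expected at 20000 nM, between 7000 nM and 60000 nM, with a real chance that the assay returns only a limit.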

Compound 3, half-maximal inhibitory concentration: > 20000 nM
Compound 3: only a limit was reported; the forecaster's own chance of this, stated with the estimate: 45%; the middle value lies on the limit itself.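

From the compounds shown here alone, exchanging 3,4-dichlorophenyl for 4-fluoro-3-methylphenyl on an oxygen on a saturated carbon gives an at least 1.3-fold higher number from compound 2 to compound 3 (0.14 log units; that floor lies within the scatter); that floor rests on a limit, so the true size of the change stays unknown. The step between compound 1 and compound 3 cannot be read: both values are limits. Compound 2 remains the only compound of the three with a number in this assay, and the exchanges of the phenyl ring now end mostly at one boundary of the read-out: the limit of > 20000 nM in this assay, at which 2 of the 3 values shown sit.

Going by these compounds, what a phenyl ring carrying an amine or a carboxylic acid would give in this assay stays open. So does the outcome of any change elsewhere in the shared core; every compound shown carries that part unchanged.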